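The source may hold more compounds than are shown below. What is called first, only, known or untested is meant among the compounds shown, and "the series" means these compounds.

compound 1 `CC#Cc1cncc(-c2ccc3c(c2)[C@@]2(COC(N)=N2)c2cc(-c4ccnc(F)c4)ncc2O3)c1`: 15 nm/s
compound 2 `COc1cc2c(cn1)Oc1ccc(NC(=O)c3ccc(Cl)cn3)cc1[C@@]21COC(N)=N1`: 25 nm/s
compound 3 `NC1=N[C@@]2(CO1)c1cc(-c3cncc(C#CC4CC4)c3)ccc1Oc1cnc(C3=CCOCC3)cc12`: 13 nm/s

All three values come from an ADME assay on LLC-PK1 cells (Sus scrofa) for permeability, read by LC-MS, with a stated time of 2 h, tested at 5 uM (on this read-out higher numbers stand for higher permeability and lower numbers for lower permeability), and lie within the usual scatter of one another. Compound 2 at 25 nm/s therefore stands level with compound 1 and compound 3 on these numbers.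

Compound 4 `NC1=N[C@@]2(CO1)c1cc(NC(=O)c3ccc(Cl)cn3)ccc1Oc1cnc(Cl)cc12` differs from compound 2 in one place, with chloro in place of methoxy on an aromatic carbon next to the ring nitrogen. Going by the values given here, no measured pair isolates this change, so the data show nothing of its size directly. Compound 1 at 15 nm/s and compound 3 at 13 nm/s carry other groups on that carbon and differ elsewhere too, yet they remain within the scatter of compound 2. The estimated 1.3-fold lower number from compound 2 to compound 4 (0.10 log units; within the scatter) is expected to stay within the scatter, and no direction can be called. Compound 4 is expected in this assay at about 20 nm/s with a likely range of 9 nm/s to 42 nm/s for a typical measurement.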

Compound 4, apparent permeability: 28 nm/s
Compound 4: the middle estimate sits 1.4-fold (0.15 log units) below what was measured; measured number inside the range.
By their numbers in this assay, from the lowest: compounds 3, 1, 2 and 4 (each within the scatter of the next, the first and the last beyond it).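

In this assay, the exchange of methoxy for chloro on an aromatic carbon next to the ring nitrogen can now be read directly, as a 1.1-fold higher number from compound 2 to compound 4 (0.05 log units; within the scatter). In this single pair, a group of two heavy atoms with a hydrogen-bond acceptor gives way to a single chlorine, which has no acceptor, and the read-out stays level. Nothing available accounts for this outcome.

How far this holds for other groups on this carbon stays open, since no amine, carboxylic acid or longer alkoxy chain appears there among the compounds shown, and compound 1 and compound 3 differ from compound 2 in more than one place. Whether the same exchange would read alike with a different group in place of the chloropyridine amide also remains unanswered.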